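Working notes: from compound 1 to compound 4

The source may report more compounds than this note shows. Statements on the series, on what has been measured and on what is new or still open speak of the compounds shown alone.

Measured in a toxicity assay on THP-1 cells (Homo sapiens) for inhibition (a lower number here means that less compound is tolerated, a higher number that more compound is tolerated), so far:
- Compound 1 `Cn1c(-c2ccccc2)cnc1NC(=O)c1ccc(F)cc1` gives > 100000 nM as a limit
- Compound 2 `Cn1c(-c2ccc(Br)cc2)cnc1NC(=O)c1ccc(F)cc1` gives 46000 nM as a number
- Compound 3 `Cn1c(-c2ccc(C#N)cc2)cnc1NC(=O)c1ccc(F)cc1` gives > 50000 nM as a limit

Compound 1 stands at the limit of > 100000 nM in this assay, at which 1 of the 3 values shown sits, and so offers no number to start from. Compound 3 is also only a limit of > 50000 nM in this assay, at which 1 of the 3 values shown sits, and gives no firmer footing.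

Among the measured compounds shown here, compound 4 `Cn1c(-c2ccccc2)cnc1NC(=O)c1cccc(Br)c1` keeps the core of compound 1 and carries 3-bromophenyl in place of 4-fluorophenyl on a carbonyl carbon as its single change.

For the measured compounds named here, no measured step makes this exact change. The nearest is the bromo step, bromo in place of hydrogen on an aromatic carbon, which gave an at least 2.1-fold lower number from compound 1 to compound 2 (0.33 log units; beyond the scatter) in the same series. Going by the values given here, that bromo stands on a different group from the one that changes in compound 4, so it is only a loose guide. The cyano steps add little, with a step that the two limits leave unreadable from compound 1 to compound 3 and an at least 1.0-fold higher number from compound 2 to compound 3 (0.03 log units; that floor lies within the scatter) as all they show.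

Because of an at least 2.1-fold lower number from compound 1 to compound 2 (0.33 log units; beyond the scatter) a modest fall in this assay is expected, and compound 4 may still reach a limit. The expected change is an at least 2.0-fold lower number from compound 1 to compound 4 (0.30 log units; that floor lies within the scatter) as an estimate only. Compound 4 is estimated at 50000 nM with an expected range from 20000 nM to 100000 nM in this read-out.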

Compound 4, half-maximal cytotoxic concentration: > 50000 nM
Compound 4 gave a limit, no number; the forecaster's own chance of this, stated with the estimate: 40%; the middle value lies on the limit itself.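

In this assay, compound 1 and compound 4 are both recorded only as limits, so the step between them cannot be read. The compounds shown leave open whether 3-bromophenyl in place of 4-fluorophenyl on a carbonyl carbon changes the tolerated concentration at all, and in which direction.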